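Propoxy in Place of Fluoro: Compound 3 Expected

The source may hold more compounds than are shown below. What is called first, only, known or untested is meant among the compounds shown, and "the series" means these compounds.

Compound 2 `CC(C)(C)c1ccc(NC(=O)c2ccc(-c3ncccc3F)cc2)cc1` gives 3 nM in a functional assay for antagonist activity at transient receptor potential cation channel subfamily V member 1 (Homo sapiens), read by FLIPR (on this read-out higher numbers stand for weaker inhibition and lower numbers for stronger inhibition), the lowest of the two numbers at hand; compound 1 `CC(C)(C)c1ccc(NC(=O)c2ccc(-c3ccccn3)cc2)cc1` gives 11 nM. Going by the values given here, the one measured step, a 3.7-fold lower number from compound 1 to compound 2 (0.56 log units; beyond the scatter), shows that a small change at this carbon can move the number beyond the scatter. Compound 3 `CCCOc1cccnc1-c1ccc(C(=O)Nc2ccc(C(C)(C)C)cc2)cc1` differs from compound 2 by propoxy in place of fluoro on an aromatic carbon. Among the compounds with values here, no measured step involves propoxy, so the direction is uncertain, and a gain like that of compound 2 cannot simply be assumed. Compound 3 is expected to give 8 nM (range 2 nM to 30 nM), an estimated step of a 2.7-fold higher number from compound 2 to compound 3 (0.43 log units; beyond the scatter).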

Compound 3, half-maximal inhibitory concentration: 62 nM
Compound 3: middle estimate off by 7.8-fold (0.89 log units), on the low side; measured number above the stated range.
By their numbers in this assay, from the lowest: compound 2; then compound 1; then compound 3.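

On this aromatic carbon, where fluoro gave a gain, this assay shows a 21-fold higher number from compound 2 to compound 3 (1.32 log units; beyond the scatter) on going to propoxy, so the direction of change depends on the group placed there. Propoxy also falls behind plain hydrogen, with a 5.6-fold higher number from compound 1 to compound 3 (0.75 log units; beyond the scatter) as the step, so the loss is more than the absence of the fluoro gain. Nothing at hand gives a reason for this loss.

The compounds shown leave open whether a shorter chain such as methoxy would stand nearer to fluoro or to propoxy. They also leave open how an amine on this carbon would compare.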